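The source may report more compounds than this note shows. Statements on the series, on what has been measured and on what is new or still open speak of the compounds shown alone.

Measured compounds:
compound 1 `Cc1n[nH]c(C)c1Oc1c(O)cc(O)c2c(=O)cc(-c3ccc(N4CCN(c5ccccc5)CC4)cc3)oc12` — 3500 nM
compound 2 `COc1c(O)cc(O)c2c(=O)cc(-c3ccc(N4CCCNCC4)cc3)oc12` — 31600 nM
compound 3 `CC(C)Oc1c(O)cc(O)c2c(=O)cc(-c3ccc(N4CCCNCC4)cc3)oc12` — 24500 nM

All three were tested in an assay on cells for inhibition of ubiquitin carboxyl-terminal hydrolase 8 (Homo sapiens), read by fluorescence, with a stated time of 30 min; a lower number here means a stronger inhibitor, a higher number a weaker inhibitor. Compound 1 gives the lowest of the three numbers; the nearest is compound 3 and the furthest is compound 2, and both of those gaps lie beyond the usual scatter. Among the compounds with values here, the only single-point step among the measured compounds is a 1.3-fold lower number from compound 2 to compound 3 (0.11 log units; within the scatter), which concerns the group on the ring oxygen of the shared core and tells nothing about the nitrogen of the six-membered ring.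

Compound 4 `Cc1n[nH]c(C)c1Oc1c(O)cc(O)c2c(=O)cc(-c3ccc(N4CCN(C(=O)c5ccco5)CC4)cc3)oc12` differs from compound 1 in this way: (furan-2-yl)carbonyl in place of phenyl on an amine nitrogen in a ring. Within the data shown here, no measured step touches this position, so the direction of the change cannot be read from the data. Compound 4 is therefore expected to give a number in this assay of 5000 nM, between 1500 nM and 16000 nM. The expected step is a 1.4-fold higher number from compound 1 to compound 4 (0.15 log units; within the scatter), a change that may well stay within the scatter.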

Compound 4, half-maximal inhibitory concentration: 5100 nM
Compound 4: the middle estimate sits 1.0-fold (0.01 log units) below what was measured, and the stated range covers the measured number.
By their numbers in this assay, from the lowest: compounds 1 and 4 (each within the scatter of the next); then compounds 3 and 2 (each within the scatter of the next).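

Within the data shown here, this is the first measured step at the amine nitrogen of the six-membered non-aromatic ring: in this assay, putting (furan-2-yl)carbonyl in place of phenyl gives a 1.5-fold higher number from compound 1 to compound 4 (0.16 log units; within the scatter). The ring at this position can thus go from a six-membered aromatic ring of carbon only to a five-membered aromatic ring with a hetero atom, joined through a carbonyl and bringing hydrogen-bond acceptors that phenyl lacks, without moving the number beyond the scatter. Nothing measured here explains why the two groups read alike.

Both groups shown on this nitrogen carry an aromatic ring, so it remains open how the number responds to a small group such as methyl. Going by these compounds, it is equally open how it responds to a longer chain ending in a carboxylic acid or an amine.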